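Adding Trifluoromethyl to Compound 3

This account rests on a few compounds, and the source may have more. Where it says the series, first, only, none or still open, it means among the compounds named here.

Values in a functional assay for inhibition, with Homo sapiens as the target; a lower number here means a stronger inhibitor, a higher number a weaker inhibitor:
- Compound 1 `CC(C)(C)Sc1c(CC(C)(C)C(=O)O)n(Cc2ccc(Cl)cc2)c2ccc(CCc3ccc4ccccc4n3)cc12`: 4 nM
- Compound 2 `CC(C)(C)Sc1c(CC(C)(C)C(=O)O)n(Cc2ccc(Cl)cc2)c2ccc(OCc3ccc4cc(F)c(F)cc4n3)cc12`: 7 nM
- Compound 3 `CC(C)(C)Sc1c(CC(C)(C)C(=O)O)n(Cc2ccc(Cl)cc2)c2ccc(OCc3nc4ccccc4s3)cc12`: 3 nM

Compound 3 cannot be separated from its nearest neighbour: a 1.3-fold lower number from compound 1 to compound 3 (0.12 log units; within the scatter). Its furthest neighbour is set apart: a 2.3-fold lower number from compound 2 to compound 3 (0.37 log units; beyond the scatter). Compound 4 `CC(C)(C)Sc1c(CC(C)(C)C(=O)O)n(Cc2ccc(Cl)cc2)c2ccc(OCc3nc4cc(C(F)(F)F)ccc4s3)cc12` carries trifluoromethyl in place of hydrogen on an aromatic carbon. Among the compounds with values here, no measured step tests this exact change. The two nearest steps replace larger groups, and both are small, so only a small change is expected in this assay, with no clear direction and probably little beyond the scatter. The expected step is a 1.7-fold higher number from compound 3 to compound 4 (0.22 log units; within the scatter). For compound 4 the estimate is 5 nM, with an expected range of 2 nM to 14 nM.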

Compound 4, half-maximal inhibitory concentration: 22 nM
For compound 4 the middle estimate is 4.4-fold (0.64 log units) below the measured one, outside the stated range (above it).
By their numbers in this assay, from the lowest: compounds 3, 1 and 2 (each within the scatter of the next, the first and the last beyond it); then compound 4.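

The step of a 7.3-fold higher number from compound 3 to compound 4 (0.87 log units; beyond the scatter) shows that this carbon of the six-membered aromatic ring does not accept trifluoromethyl freely. The earlier compounds shown here swapped whole groups on the shared core and stayed within a narrow span, so they gave no sign that adding a single substituent here could cost this much activity. No measurement given here explains the loss. From the compounds shown here alone, what remains open is whether the loss belongs to this carbon or to trifluoromethyl itself. A fluorine or methyl group on the same carbon would help separate the two.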